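Two bis-pyrazole nitrophenyl analogues and an octyloxy extension

The compounds below may be only part of what the source reports. "The series", "measured", "known", "first", "only" and "open" are said of these compounds alone.

Measured so far:
Compound 1 `O=[N+]([O-])c1ccc(-n2cc(-c3ccc(C(F)(F)F)cc3)cn2)cc1`, in a functional assay on HL-60 cells (Homo sapiens) for cytotoxicity, read by MTT assay, with a stated time of 48 h (on this read-out higher numbers stand for weaker inhibition and lower numbers for stronger inhibition), compound 1 gives 17300 nM.
Compound 2 `Cc1nn(-c2ccc([N+](=O)[O-])cc2)c(C)c1-c1cccc(-c2c(C)nn(-c3ccc([N+](=O)[O-])cc3)c2C)c1`, in this assay compound 2 gives 10600 nM.

Compound 2 holds the lower of the two numbers recorded, yet its gap to compound 1 lies within the usual scatter, so the two cannot be ranked against each other. Among the measured compounds shown here, compound 1 and compound 2 differ in several places at once, and no single step between them is defined; only their two values can be compared.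

Compound 3 `CCCCCCCCOc1cc(-c2c(C)nn(-c3ccc([N+](=O)[O-])cc3)c2C)cc(-c2c(C)nn(-c3ccc([N+](=O)[O-])cc3)c2C)c1` follows from compound 2 by one change: octyloxy in place of hydrogen on an aromatic carbon, on an aromatic carbon of a six-membered aromatic ring of carbon only, meta to two large groups. For the measured compounds named here, no measured step of this kind exists, so there is nothing to calibrate the expectation against. A step of modest size toward a lower number, or none beyond the scatter, is the working expectation for the move from compound 2 to compound 3, expressed as a 1.5-fold lower number from compound 2 to compound 3 (0.18 log units; within the scatter). Compound 3 is estimated at 7000 nM, with a range from 2000 nM to 30000 nM.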

Compound 3, half-maximal inhibitory concentration: 7910 nM
Beside the measured number, compound 3's estimate is 1.1-fold (0.05 log units) below it, and the stated range covers the measured number.
By their numbers in this assay, from the lowest: compounds 3, 2 and 1 (each within the scatter of the next, the first and the last beyond it).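

In this assay, octyloxy in place of hydrogen on an aromatic carbon, meta to two large groups, gives a 1.3-fold lower number from compound 2 to compound 3 (0.13 log units; within the scatter), so compound 2 and compound 3 cannot be ranked against each other. Among the compounds shown here, this is the first defined single-place step, and it shows that this position can carry a chain of 9 heavy atoms, with no ring and one hydrogen-bond acceptor, without a shift beyond the scatter in this cytotoxicity read-out. No measurement at hand offers an explanation for this result.

One step at one position cannot show whether the outcome depends on the chain, on its oxygen link or on the position itself, so a methoxy group, a longer alkoxy chain, or a plain octyl chain joined directly to the aromatic carbon would each test a different part of the change. As far as these compounds go, whether an amine or a carboxylic acid at the end of such a chain would give a step beyond the scatter also remains open.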